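Compound 3 in the BJ cytotoxicity series

This account rests on a few compounds, and the source may have more. Where it says the series, first, only, none or still open, it means among the compounds named here.

compound 1 `Cc1cc(NC(=O)Nc2ccc(C(C)(C)C)cc2)c2ccccc2n1`: 20000 nM
compound 2 `CSc1ccc(NC(=O)Nc2cc(C)nc3ccccc23)cc1`: > 25000 nM (a limit)

In an ADME assay on BJ cells (Homo sapiens) for cytotoxicity, with a stated time of 72 h (a lower number here means that less compound is needed, a higher number that more compound is needed for the effect), compound 2 gives > 25000 nM, which is a limit of the assay and not a number. The change to compound 3 `CCc1ccc(NC(=O)Nc2cc(C)nc3ccccc23)cc1` is ethyl in place of methylsulfanyl on an aromatic carbon. Among the compounds with values here, the one measured step, methylsulfanyl in place of tert-butyl, is an at least 1.2-fold higher number from compound 1 to compound 2 (0.09 log units; that floor lies within the scatter). On that evidence, the expected step in this assay is an at least 1.1-fold lower number from compound 2 to compound 3 (0.05 log units; that floor lies within the scatter), with none expected beyond the scatter. For compound 3 the estimate is 22000 nM, with an expected range of 11000 nM to 45000 nM.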

Compound 3, half-maximal effective concentration: > 25000 nM
Compound 3: no number, only a limit; the forecaster's own chance of this, stated with the estimate: 45%; middle value at least 1.1-fold (0.05 log units) away from the limit.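

In this assay compound 3 gives > 25000 nM, which is a limit of the assay and not a number. The change from methylsulfanyl to ethyl cannot be read, because both compounds stop at the same limit: the limit of > 25000 nM in this assay, at which 2 of the 3 values shown sit. Against tert-butyl, the one readable step is an at least 1.2-fold higher number from compound 1 to compound 3 (0.09 log units; that floor lies within the scatter), so ethyl, like methylsulfanyl, is not separated from tert-butyl beyond the scatter. Going by these compounds, whether ethyl and methylsulfanyl differ at all in this assay remains open. So does whether an amine or a carboxylic acid at this position would give a measurable value.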